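Adding a Methyl Group at a New Carbon

A few compounds are considered here, and "the series" means these few. Any claim that something is new, unique, unknown or untested is made for them only; others in the source may bear on it.

Among the measured compounds shown here, in a functional assay on HCT-116 cells (Homo sapiens) for antiproliferative activity (on this read-out higher numbers stand for weaker inhibition of growth and lower numbers for stronger inhibition of growth), compound 1 `Oc1cc(-c2ccc3ccccc3c2)nc2ncccc12` gives 3800 nM, the higher of the two numbers measured so far, which makes it the weaker growth inhibitor of the pair. For the measured compounds named here, the only comparison is compound 2 `Cc1ccnc2nc(-c3ccc4ccccc4c3)cc(O)c12`, which gives 427 nM and carries a methyl in place of hydrogen on an aromatic carbon of the core.

Compound 3 `Cc1ccc2c(O)cc(-c3ccc4ccccc4c3)nc2n1` has not yet been measured. It differs from compound 1 by the same kind of change, (methyl in place of hydrogen on an aromatic carbon), but on a different carbon, the one next to the ring nitrogen. Going by the values given here, only one measured step bears on this change, and it comes from another carbon, so it is a limited guide. Resting on that single step, an 8.9-fold lower number from compound 1 to compound 2 (0.95 log units; beyond the scatter), which lies beyond the scatter, a smaller step in the same direction is expected in this assay. The estimated step is a 2.5-fold lower number from compound 1 to compound 3 (0.40 log units; beyond the scatter). For compound 3 the expected value is 1500 nM, with an estimated range from 400 nM to 5000 nM.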

Compound 3, concentration for 50% growth inhibition: 3980 nM
Beside the measured number, compound 3's estimate is 2.7-fold (0.42 log units) below it, and the stated range covers the measured number.
By their numbers in this assay, from the lowest: compound 2; then compounds 1 and 3 (each within the scatter of the next).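

In this assay, methyl in place of hydrogen on the aromatic carbon next to the ring nitrogen gives a 1.0-fold higher number from compound 1 to compound 3 (0.02 log units; within the scatter), so at this position the change has no effect that can be told from the scatter. The earlier step, an 8.9-fold lower number from compound 1 to compound 2 (0.95 log units; beyond the scatter), came from the same exchange on another carbon of the core, which shows that the stronger growth inhibition seen there does not follow from adding a methyl group to just any aromatic carbon of this core: the outcome depends on which carbon carries it. Nothing available here explains why the two carbons behave differently.

The compounds shown leave open whether this carbon is simply insensitive to substitution or whether a different group placed there, such as an amine, a methoxy group or a longer chain like propyl, would shift the number in either direction. They also leave open whether the other carbon's response is particular to methyl, and what methyl groups on both carbons together would do.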